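From a five-membered to a six-membered amine ring

A few compounds are considered here, and "the series" means these few. Any claim that something is new, unique, unknown or untested is made for them only; others in the source may bear on it.

Of the compounds shown here, three sharing one core have been measured in an assay on CHO-K1 cells for antagonist activity at adenosine receptor A1 (Homo sapiens), read by a beta-galactosidase reporter, with stated times of 15 min and 6 h; a lower number here means a stronger inhibitor, a higher number a weaker inhibitor. Compound 1 `Nc1nc(-c2ccco2)nc2sc(CN3CC=CCC3)cc12` gives 150 nM, and compound 2 `Nc1nc(-c2ccc(Cl)o2)nc2sc(CN3CC=CCC3)cc12` gives 190 nM. Among the compounds with values here, the one measured step, a 1.3-fold higher number from compound 1 to compound 2 (0.10 log units; within the scatter), stays within the scatter. Compound 3 `Nc1nc(-c2ncco2)nc2sc(CN3CC=CC3)cc12` gives 3890 nM, the highest of the three numbers, and it lies beyond the scatter above both compound 2 and compound 1. Compound 3 differs from compound 1 in two places at once, so neither place can be judged on its own from the numbers at hand.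

Compound 4 `Nc1nc(-c2ncco2)nc2sc(CN3CC=CCC3)cc12` has not yet been measured. Its change from compound 3 is a group of 6 heavy atoms (5 carbon, 1 nitrogen; one six-membered non-aromatic ring with 1 hetero atom) in place of a group of 5 heavy atoms (4 carbon, 1 nitrogen; one five-membered non-aromatic ring with 1 hetero atom), on a saturated chain carbon bound to an aromatic carbon. Within the data shown here, no measured step covers this change: the step from compound 1 to compound 2 concerns only a chloro group on an aromatic carbon. Compound 4 shares the entering six-membered ring with compound 1 and the rest of its structure with compound 3, so its number is expected to fall between those two, and the step of a 3.9-fold lower number from compound 3 to compound 4 (0.59 log units; beyond the scatter) is expected to run downward, with its size uncertain. For compound 4 the estimate in this assay is 1000 nM, with a range from 250 nM to 4000 nM.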

Compound 4, inhibition constant: 2960 nM
Beside the measured number, compound 4's estimate is 3.0-fold (0.47 log units) below it, within the range that was stated.
By their numbers in this assay, from the lowest: compounds 1 and 2 (each within the scatter of the next); then compounds 4 and 3 (each within the scatter of the next).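

In this assay the six-membered amine ring in place of the five-membered one, on a saturated chain carbon bound to an aromatic carbon, gives a 1.3-fold lower number from compound 3 to compound 4 (0.12 log units; within the scatter) and so makes no clear difference while the 1,3-oxazol-2-yl group is present. The other two steps change only the aromatic group: 1,3-oxazol-2-yl in place of furan-2-yl gives a 20-fold higher number from compound 1 to compound 4 (1.30 log units; beyond the scatter) and 1,3-oxazol-2-yl in place of 5-chlorofuran-2-yl gives a 16-fold higher number from compound 2 to compound 4 (1.19 log units; beyond the scatter) in the same assay. Among these compounds, then, the large shift in the number follows the change of aromatic group, and the change of amine ring size leaves the number within the scatter.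

Still open, going by these compounds, is whether ring size is equally unimportant with furan-2-yl in place, since only the six-membered ring appears with that group here, and how a morpholine ring or an open-chain diethylamine would behave at the same position. Nothing available gives a measured reason for either the large steps or the small one.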